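Truncation of the pyrazolylamino arm on the shared core

A few compounds are considered here, and "the series" means these few. Any claim that something is new, unique, unknown or untested is made for them only; others in the source may bear on it.

Of the compounds shown here, three share a common core and have been measured in an assay on isolated protein for inhibition of Leucine-rich repeat serine/threonine-protein kinase 2 (Homo sapiens), read by TR-FRET and LanthaScreen, with stated times of 50 min and 30 min, in the presence of a further agent that is not named here; on this read-out lower numbers stand for stronger inhibition and higher numbers for weaker inhibition. Compound 1 `Cc1c(Nc2nc(N)c3c(C#N)c(N4CCC[C@H]4C)n(C)c3n2)cnn1CC(C)(C)O` gives 43 nM. Compound 2 `C[C@@H]1CCCN1c1c(C#N)c2c(N)nc(Nc3cn(C)nc3Cl)nc2n1C` gives 34 nM, the lowest of the three numbers, though its gap to compound 1 lies within the scatter, so no order between these two is claimed. Compound 3 `Cc1cn(C)nc1Nc1cc2c(c(N)n1)c(C#N)c(N1CCC[C@H]1C)n2C`, in which the amino linkage is attached to a different ring position of the core, gives 2110 nM, well beyond the scatter from both others.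

Compound 4 `C[C@@H]1CCCN1c1c(C#N)c2c(N)ncnc2n1C` has not been measured. It differs from compound 2 by hydrogen in place of (3-chloro-1-methyl-1H-pyrazol-4-yl)amino on an aromatic carbon. Nothing in the measured set tests removal of this whole substituent; the nearest comparison is compound 3, where a change in how the arm is attached already costs a large step. Loss of the entire arm, with its hydrogen-bond donor and three acceptors, is expected to cost more, so a large step upward is expected, a 590-fold higher number from compound 2 to compound 4 (2.77 log units; beyond the scatter). For compound 4 in this assay the expected value is 20000 nM, with a range of 3000 nM to 100000 nM; a limit rather than a number is quite possible.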

Compound 4, half-maximal inhibitory concentration: 15 nM
Compound 4: middle estimate off by 1300-fold (3.12 log units), on the high side; the whole stated range lies above it.
By their numbers in this assay, from the lowest: compound 4; then compounds 2 and 1 (each within the scatter of the next); then compound 3.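

In this assay, hydrogen in place of (3-chloro-1-methyl-1H-pyrazol-4-yl)amino on the aromatic carbon between two ring nitrogen atoms gives a 2.3-fold lower number from compound 2 to compound 4 (0.36 log units; beyond the scatter) as a modest step beyond the scatter. At this position, then, the whole arm with its five-membered aromatic ring is not needed for a low number on this read-out, which compound 1, compound 2 and compound 3 could not show, as all three carry an arm. Nothing available accounts for the number falling rather than rising when the arm leaves.

Going by these compounds, whether a small group on this carbon, such as an amine, a methyl or a chlorine, keeps the number of compound 4 remains open. So does the effect of a shorter arm such as methylamino, which would show how much of the pyrazolylamino arm can go before the number changes.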